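Furan-3-yl in Place of Ethynyl on Compound 1

The source may hold more compounds than are shown below. What is called first, only, known or untested is meant among the compounds shown, and "the series" means these compounds.

Compound 1 `C#Cc1cn([C@@H]2O[C@H](CO)[C@@H](O)[C@H]2O)c2ncnc(NC)c12`: > 20000 nM in a functional assay on CCRF-CEM cells (Homo sapiens), read by MTT assay, with a stated time of 72 h; a lower number here means a stronger inhibitor, a higher number a weaker inhibitor
Compound 2 `C#Cc1cn([C@@H]2O[C@H](CO)[C@@H](O)[C@H]2O)c2ncnc(OC)c12`: > 20000 nM in this assay
Compound 3 `C#Cc1cn([C@@H]2O[C@H](CO)[C@@H](O)[C@H]2O)c2ncnc(SC)c12`: > 20000 nM in this assay

All three values are limits, not numbers, so compound 1 stands at the limit of this assay (the limit of > 20000 nM in this assay, at which 3 of the 3 values shown sit). The steps a step that the two limits leave unreadable from compound 1 to compound 2, a step that the two limits leave unreadable from compound 1 to compound 3 and a step that the two limits leave unreadable from compound 2 to compound 3 are therefore unreadable, and each of them concerns a different place on the core than the change studied here. Compound 4 `CNc1ncnc2c1c(-c1ccoc1)cn2[C@@H]1O[C@H](CO)[C@@H](O)[C@H]1O` differs from compound 1 by furan-3-yl in place of ethynyl on an aromatic carbon. Within the data shown here, no measured step bears on this change, so no direction can be read from the data. Compound 4 is expected to remain near the limit, with an estimated step that the limit leaves unreadable from compound 1 to compound 4. The estimate for compound 4 is 25000 nM, in a range from 8000 nM to 80000 nM.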

Compound 4, half-maximal inhibitory concentration: > 20000 nM
Compound 4 gave a limit, no number; the forecaster's own chance of this, stated with the estimate: 70%; the middle value lies beyond the limit too.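

Among these compounds, compound 4 gives > 20000 nM in this assay, which is a limit and not a number, and no step from compound 1 to compound 4 can be read. The compounds shown leave open how furan-3-yl and ethynyl compare, as all values rest at one limit: the limit of > 20000 nM in this assay, at which 4 of the 4 values shown sit.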